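The source may report more compounds than this note shows. Statements on the series, on what has been measured and on what is new or still open speak of the compounds shown alone.

For the measured compounds named here, in a functional assay (aorta) with Rattus norvegicus as the target (a lower number here means that less compound is needed, a higher number that more compound is needed for the effect), compound 2 `CNC(=O)C1=CC(C)(C(F)(F)F)Oc2ccc([N+](=O)[O-])cc21` gives 2.69 nM, the higher of the two numbers so far, and compound 1 `C/N=C(/S)C1=CC(C(F)(F)F)(C(F)(F)F)Oc2ccc([N+](=O)[O-])cc21` gives 0.631 nM, a gap beyond the scatter. Compound 3 `CNC(=O)C1=CC(C(F)(F)F)(C(F)(F)F)Oc2ccc([N+](=O)[O-])cc21` has trifluoromethyl in place of methyl on a saturated ring carbon, next to the ring oxygen (trifluoromethyl in place of methyl on a saturated ring carbon). Going by the values given here, no measured step isolates this change. A small move to a lower number in this assay, near the scatter, is expected, resting on compound 1 at 0.631 nM, which also carries trifluoromethyl in place of that methyl. The expected step is a 1.9-fold lower number from compound 2 to compound 3 (0.28 log units; within the scatter). Compound 3 is estimated at 1.4 nM, with a range of 0.4 nM to 5 nM.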

Compound 3, half-maximal effective concentration: 1.48 nM
Compound 3: middle estimate off by 1.1-fold (0.02 log units), on the low side; low and high end bracket the measured number.
By their numbers in this assay, from the lowest: compound 1; then compounds 3 and 2 (each within the scatter of the next).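

In this assay, the change to trifluoromethyl in place of methyl on the saturated ring carbon, next to the ring oxygen, now stands alone: a 1.8-fold lower number from compound 2 to compound 3 (0.26 log units; within the scatter), so the two groups are not told apart here. For the compounds shown here, the one step beyond the scatter in this pair of new steps lies elsewhere, on the double-bonded ring carbon, where the oxygen-bearing group replaces the sulfur-bearing group: a 2.3-fold higher number from compound 1 to compound 3 (0.37 log units; beyond the scatter). No measurement at hand bears on the reason for either step. Open, going by these compounds, is whether ethyl or a hydroxymethyl group on that saturated ring carbon would also stay within the scatter. Also open, on these data alone, is whether the step on the double-bonded ring carbon holds with methyl on the saturated ring carbon.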